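Working notes: benzyl to 2-fluorobenzyl from compound 2

This account rests on a few compounds, and the source may have more. Where it says the series, first, only, none or still open, it means among the compounds named here.

Measured in a functional assay on MDA-MB-231 cells (Homo sapiens) for cytotoxicity, read by MTT assay, with a stated time of 48 h; a higher number here means a weaker inhibitor, a lower number a stronger inhibitor:
- compound 1 `O=C(O)CN1C(=O)/C(=C/c2nc3ccccc3n2Cc2ccc([N+](=O)[O-])cc2)SC1=S` gives 7760 nM here
- compound 2 `O=C(O)CN1C(=O)/C(=C/c2nc3ccccc3n2Cc2ccccc2)SC1=S` gives 1820 nM here

Compound 2 holds the lower of the two numbers, and its gap to compound 1 is beyond the scatter. Compound 3 `O=C(O)CN1C(=O)/C(=C/c2nc3ccccc3n2Cc2ccccc2F)SC1=S` has not yet been measured. It carries fluoro in place of hydrogen on an aromatic carbon, ortho to a large group: fluoro in place of hydrogen on an aromatic carbon on the core of compound 2.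

Among the compounds with values here, only one measured step bears on this change, and only indirectly. The step of a 4.3-fold lower number from compound 1 to compound 2 (0.63 log units; beyond the scatter) is modest and beyond the scatter, with hydrogen in place of nitro on an aromatic carbon. Within the data shown here, it concerns a different group, and no fluoro compound has been measured, so it sets no direct size for the new change. It does leave open a small rise in the number, but no step beyond the scatter is expected. The expected step is a 1.1-fold higher number from compound 2 to compound 3 (0.04 log units; within the scatter) in this estimate. For compound 3 the estimated value in this assay is 2000 nM, with an expected range from 800 nM to 4500 nM.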

Compound 3, half-maximal inhibitory concentration: 330 nM
Compound 3: the middle estimate sits 6.1-fold (0.78 log units) above what was measured, and the stated range ends above it.
By their numbers in this assay, from the lowest: compound 3; then compound 2; then compound 1.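

In this assay, this position responds strongly to a single added heavy atom: fluoro in place of hydrogen on an aromatic carbon, ortho to a large group, gives a 5.5-fold lower number from compound 2 to compound 3 (0.74 log units; beyond the scatter) and places the smallest number of the series on the 2-fluorobenzyl compound. The earlier nitro step showed only that one substituent on the benzyl group could raise the number relative to plain benzyl; the substituent can now also lower it, and the two substituted forms are separated by a 24-fold lower number from compound 1 to compound 3 (1.37 log units; beyond the scatter) even though the rest of the structure is shared. Nothing available gives a reason for the size or direction of these steps.

Whether the fluoro step belongs to fluoro as such or to its place ortho to a large group stays open; among the compounds shown, fluoro appears at that one place only. Also open, on these data alone, is how chloro, methoxy or an amine at the same place would read, and whether a second fluoro on this phenyl would lower the number further or raise it again.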